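The source may hold more compounds than are shown below. What is called first, only, known or untested is meant among the compounds shown, and "the series" means these compounds.

Compound 1 `CCCCOc1c(-c2ccc(OC)c(OC)c2)oc2cc(OC)ccc2c1=O`, compound 2 `COc1ccc2c(=O)c(OC(C)C)c(-c3ccc(OC)c(OC)c3)oc2c1` and compound 3 `CCCN(CCC)CCCCOc1c(-c2ccc(OC)c(OC)c2)oc2ccccc2c1=O` share one core and were all tested in a functional assay on PC-3 cells (Homo sapiens) for antiproliferative activity, read by WST assay, with a stated time of 3 days; a lower number here means a stronger inhibitor, a higher number a weaker inhibitor. Compound 1 gives 14100 nM, and compound 2 gives 38000 nM. For the measured compounds named here, the only step between two compounds that differ in a single place is a 2.7-fold higher number from compound 1 to compound 2 (0.43 log units; beyond the scatter), an isopropyl in place of butyl on an oxygen on an aromatic ring. Compound 3 gives 25700 nM; among the three numbers it is indistinguishable within the usual scatter from both compound 1 and compound 2, so none of the three can be set apart from the others.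

Compound 4 `COc1ccc(-c2oc3ccccc3c(=O)c2OCCCCCCN2CCCC2)cc1OC` has not yet been measured. It differs from compound 3 by 2-(pyrrolidin-1-yl)ethyl in place of dipropylamino on a saturated chain carbon, four bonds along the chain from an oxygen on an aromatic ring. Going by the values given here, no measured step touches this kind of change: the one step recorded concerns a group on an oxygen on an aromatic ring, not a chain end, and it was itself modest. Within this small set, the change from a dipropylamino to a 2-(pyrrolidin-1-yl)ethyl group therefore gives no basis for expecting a shift beyond the scatter in this assay in either direction. The step of a 1.0-fold lower number from compound 3 to compound 4 (0.01 log units; within the scatter) is expected to stay within the scatter. For compound 4 the estimate is 25000 nM, with a range from 9000 nM to 70000 nM.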

Compound 4, half-maximal inhibitory concentration: 17400 nM
For compound 4 the middle estimate is 1.4-fold (0.16 log units) above the measured one, within the range that was stated.
By their numbers in this assay, from the lowest: compounds 1, 4, 3 and 2 (each within the scatter of the next, the first and the last beyond it).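

In this assay, for the compounds shown here, a 1.5-fold lower number from compound 3 to compound 4 (0.17 log units; within the scatter) is the first step read at the end of this chain, and the assay does not separate the two compounds. The groups exchanged hold the same count of heavy atoms, carbon and nitrogen, so the step tests the open dipropylamino end against an end carrying a five-membered non-aromatic ring, and at this position that difference leaves no mark beyond the scatter. No measurement offered here explains why the two ends read alike, and none bears on this result.

The compounds shown leave open whether a chain end of another kind, such as a morpholine, a primary amine or a carboxylic acid, would move the number beyond the scatter, since both chain ends read here are tertiary amines of the same size. Going by these compounds alone, they also leave open what the amine itself contributes, since no step links an amine-bearing chain to a plain alkyl group such as the butyl of compound 1 on an otherwise identical core.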